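Trifluoromethyl for ethyl on a weak growth inhibitor

The compounds below may be only part of what the source reports. "The series", "measured", "known", "first", "only" and "open" are said of these compounds alone.

For the measured compounds named here, in a functional assay on MCF7 cells (Homo sapiens) for cytotoxicity, read by MTT assay, with a stated time of 48 h (on this read-out higher numbers stand for weaker inhibition of growth and lower numbers for stronger inhibition of growth), compound 2 (`CCc1nc2cc(Cl)c(Cl)cc2n1C1CCCC1`) gives 52000 nM as the higher of the two numbers so far, and compound 1 (`FC(F)(F)c1nc2cc(Cl)c(Cl)cc2n1Cc1ccccc1`) gives 8700 nM on the same read-out. The gap between these two numbers lies beyond the scatter. Compound 3 (`FC(F)(F)c1nc2cc(Cl)c(Cl)cc2n1C1CCCC1`) keeps the cyclopentyl group but has trifluoromethyl in place of ethyl on an aromatic carbon. Compound 1 also carries trifluoromethyl and gives 8700 nM but lacks the cyclopentyl group, so it is only a loose guide. A moderate drop beyond the scatter is expected in this assay and the estimated step is a 3.3-fold lower number from compound 2 to compound 3 (0.51 log units; beyond the scatter) in size. The expected value for compound 3 is 16000 nM within an estimated range of 6000 nM to 42000 nM overall.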

Compound 3, concentration for 50% growth inhibition: 21000 nM
Beside the measured number, compound 3's estimate is 1.3-fold (0.12 log units) below it; the range from low to high includes it.
By their numbers in this assay, from the lowest: compound 1; then compound 3; then compound 2.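

With the cyclopentyl group held fixed, trifluoromethyl in place of ethyl on the aromatic carbon between two ring nitrogen atoms gives a 2.5-fold lower number from compound 2 to compound 3 (0.39 log units; beyond the scatter) in this assay, so this position responds to the change, though modestly. With trifluoromethyl held fixed, cyclopentyl in place of benzyl on the aromatic nitrogen gives a 2.4-fold higher number from compound 1 to compound 3 (0.38 log units; beyond the scatter), so the group on that nitrogen matters too. Nothing available explains either step.

As far as these compounds go, whether an amine or a carboxylic acid on that aromatic carbon would give a lower or higher number remains open. So does the effect of a longer chain there.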